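Removing the hydroxy from compound 3

A few compounds are considered here, and "the series" means these few. Any claim that something is new, unique, unknown or untested is made for them only; others in the source may bear on it.

Measured in a functional assay on cells (Ovarian carcinoma cell, Homo sapiens) for cytotoxicity, read by sulforhodamine B assay, with a stated time of 48 h; on this read-out higher numbers stand for weaker inhibition of growth and lower numbers for stronger inhibition of growth:
- Compound 1 `COc1nc2sc(C)cn2c1C=C1C(=O)N(C)c2ccccc21` gives 10500 nM
- Compound 2 `COc1ccc2c(c1)/C(=C\c1c(OC)nc3sc(C)cn13)C(=O)N2` gives 1320 nM
- Compound 3 `COc1nc2sc(C)cn2c1/C=C1/C(=O)Nc2ccc(O)cc21` gives 12900 nM

Compound 3, at 12900 nM, lies within the scatter of compound 1 and well above compound 2. The next compound, compound 4 `COc1nc2sc(C)cn2c1/C=C1/C(=O)Nc2ccccc21`, has hydrogen in place of hydroxy on an aromatic carbon.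

Among the compounds with values here, only one measured step touches this carbon. Taking the methyl off the oxygen there gave a 9.8-fold higher number from compound 2 to compound 3 (0.99 log units; beyond the scatter), so the group at this place can matter, but no measured step removes the oxygen itself. Compound 1 also has no oxygen group there, yet it carries an extra methyl on the amide nitrogen, and compound 1 gives 10500 nM. This points to a small change at most, perhaps towards stronger inhibition in this assay. The expected change is a 2.6-fold lower number from compound 3 to compound 4 (0.41 log units; beyond the scatter). For compound 4 the estimated value is 5000 nM, with an expected range of 1500 nM to 14000 nM.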

Compound 4, concentration for 50% growth inhibition: 6290 nM
Compound 4: middle estimate off by 1.3-fold (0.10 log units), on the low side; measured number inside the range.
By their numbers in this assay, from the lowest: compound 2; then compounds 4, 1 and 3 (each within the scatter of the next, the first and the last beyond it).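

In this assay the step is a 2.1-fold lower number from compound 3 to compound 4 (0.31 log units; beyond the scatter) when hydroxy leaves and a 4.8-fold higher number from compound 2 to compound 4 (0.68 log units; beyond the scatter) when methoxy leaves, so this aromatic carbon can now be judged with no oxygen group on it at all. An oxygen here therefore does not act in one fixed direction: against plain hydrogen, the methoxy goes with stronger inhibition of growth and the hydroxy with weaker inhibition. No measured evidence is available to explain this order.

The compounds shown carry only hydrogen, hydroxy and methoxy at this place, so it remains open where an amine, a fluorine atom or a longer ether such as ethoxy would fall. Compound 1 alone has the methyl on the amide nitrogen, which leaves open whether the same order holds with that methyl present.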